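The source may hold more compounds than are shown below. What is called first, only, known or untested is meant among the compounds shown, and "the series" means these compounds.

Three compounds set the frame. Compound 1 `COc1ccc(CN(C(=O)C2CC2)c2cc(OC)c(OC)c(OC)c2)cc1O` gives 80 nM in a functional assay on KYSE-450 cells (Homo sapiens) for inhibition, read by MTT assay, with a stated time of 48 h (a lower number here means a stronger inhibitor, a higher number a weaker inhibitor), the lowest of the three numbers. Compound 3 `COc1ccc(CNc2cc(OC)c(OC)c(OC)c2)cc1N` gives 2210 nM, and compound 2 `COc1cc(NCc2cccc(O)c2)cc(OC)c1OC` gives 71300 nM; both gaps to compound 1 lie beyond the usual scatter of the assay, so compound 1 stands clearly apart from the other two, and it is the starting point for the next step.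

The unmeasured compound 4 `COc1ccc(CN(C(=O)CO)c2cc(OC)c(OC)c(OC)c2)cc1O` keeps the core of compound 1 and changes only the acyl group on the amide nitrogen: hydroxymethyl in place of cyclopropyl on a carbonyl carbon. The rest of the molecule, including the trimethoxyphenyl portion and the substituted benzyl portion, is unchanged.

Among the measured compounds shown here, no step between measured compounds resembles this exchange, so the expectation rests on compound 1 alone. Compound 1 is expected to lose some potency in the step of a 3.1-fold higher number from compound 1 to compound 4 (0.49 log units; beyond the scatter), a modest change rather than a collapse. For compound 4 the estimate is 250 nM, with a likely range from 50 nM to 1500 nM.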

Compound 4, half-maximal inhibitory concentration: 370 nM
Compound 4: the middle estimate sits 1.5-fold (0.17 log units) below what was measured; measured number inside the range.
By their numbers in this assay, from the lowest: compound 1; then compound 4; then compound 3; then compound 2.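

Among the compounds shown here, with everything else held fixed, hydroxymethyl in place of cyclopropyl on a carbonyl carbon gives the first single-change reading at this position, and in this assay it is a modest loss (a 4.6-fold higher number from compound 1 to compound 4 (0.67 log units; beyond the scatter)). The step lies beyond the scatter, yet an open group with a hydrogen-bond donor and acceptor can replace a carbon-only three-membered ring with neither, and the activity falls without collapsing. Nothing measured here explains why the number rises.

This one exchange removes the ring and adds the oxygen together, so the compounds shown cannot separate those two changes. Also open, as far as these compounds go, is how an amine, a carboxylic acid, a plain methyl or a longer carbon chain on this carbonyl carbon would compare with cyclopropyl and hydroxymethyl.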